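This account rests on a few compounds, and the source may have more. Where it says the series, first, only, none or still open, it means among the compounds named here.

Three compounds that share a core have been compared in a functional assay; on this read-out higher numbers stand for weaker inhibition and lower numbers for stronger inhibition. Compound 1, `O=c1cc(/C=C/c2ccccc2)oc2cc(O)cc(O)c12`, gives 5700 nM, the lowest of the three numbers. Compound 2, `O=c1cc(/C=C/c2ccc(O)c(O)c2)oc2ccccc12`, gives 31200 nM, and compound 3, `O=c1cc(/C=C/c2ccc(O)c(O)c2)oc2cccc(O)c12`, gives 16900 nM; both of these numbers lie higher than that of compound 1, each by a gap beyond the usual scatter. The difference between the core of compound 1 and the core of compound 3 is not broken down here. Within the pair of compounds 3 and 2 the change is counted: hydrogen in place of hydroxy on an aromatic carbon. The matching step is a 1.8-fold higher number from compound 3 to compound 2 (0.27 log units; within the scatter), a movement that stays within the scatter of repeated measurements.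

Compound 4, `O=c1cc(/C=C/c2ccccc2)oc2cc(O)ccc12`, has not yet been measured in this assay. It differs from compound 1 in one place: hydrogen in place of hydroxy on an aromatic carbon. This is the same kind of change as that from compound 3 to compound 2, though not the same, since in compound 1 the place is also meta to a hydroxy group (1 heavy atom), which the place in compound 3 is not. The step of a 1.6-fold higher number from compound 1 to compound 4 (0.20 log units; within the scatter) is expected. Among the compounds with values here, that expectation rests on the measured step of a 1.8-fold higher number from compound 3 to compound 2 (0.27 log units; within the scatter), the only instance of this change with a number on both sides. In this assay compound 4 is therefore estimated at 9000 nM, with a likely range from 4000 nM to 25000 nM.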

Compound 4, half-maximal inhibitory concentration: 72300 nM
The estimate for compound 4 lay 8.0-fold (0.90 log units) below the measured number; measured number above the stated range.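

In this assay, within the data shown here, putting hydrogen in place of hydroxy on the core of compound 1 gave a 13-fold higher number from compound 1 to compound 4 (1.10 log units; beyond the scatter), and this step does not match the only earlier instance of the change, which stayed within the scatter on the other core: the same change on two cores in this assay, a 1.8-fold higher number (0.27 log units; within the scatter) from compound 3 to compound 2 and a 13-fold higher number (1.10 log units; beyond the scatter) from compound 1 to compound 4, 6.9-fold (0.84 log units) apart, beyond the scatter of two such steps. In this series, then, the replacement of hydroxy by hydrogen on an aromatic carbon did not carry over as one fixed step, and the size measured on one core gave no reliable guide to its size on the other. What the two steps do not show is why they differ, since they are only two instances, the two cores differ in more than one place, and nothing here separates the contribution of any one of those differences.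

The compounds shown leave open whether a methoxy group or an amine in that same place on the core of compound 1 would move the number as far as hydrogen does. They also leave open what would follow on the same core from replacing the hydroxy group that remains in compound 4.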